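A few compounds are considered here, and "the series" means these few. Any claim that something is new, unique, unknown or untested is made for them only; others in the source may bear on it.

Notes on the series with a shared core. Compound 1 `C#CCN(C)Cc1ccc(NC(=O)CCC(=O)NO)cc1` in a functional assay on DU-145 cells (Homo sapiens) for inhibition, read by MTT assay, with a stated time of 48 h (on this read-out lower numbers stand for stronger inhibition of growth and higher numbers for weaker inhibition of growth), gives > 10000 nM, which is a limit of the assay and not a number. Compound 2 `C#CCN(C)Cc1ccc(NC(=O)CCCC(=O)NO)cc1` in this assay gives > 10000 nM, again a limit. Compound 3 `C#CCN(C)Cc1ccc(NC(=O)CCCCC(=O)NO)cc1` in this assay gives > 10000 nM, once more a limit, so compound 3 stands only at a limit and nothing places it above or below the other two. The measured steps are a step that the two limits leave unreadable from compound 1 to compound 2, a step that the two limits leave unreadable from compound 1 to compound 3 and a step that the two limits leave unreadable from compound 2 to compound 3; each is unreadable because of the limit of > 10000 nM in this assay, at which 3 of the 3 values shown sit.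

Compound 4 `C#CCN(C)Cc1ccc(NC(=O)CCCCCC(=O)NO)cc1` is not yet measured. It differs from compound 3 by (hydroxycarbamoyl)methyl in place of hydroxycarbamoyl on a saturated chain carbon, four bonds along the chain from a carbonyl carbon. The three steps above are the ones that bear on this change, since each also lengthens the chain by the same kind of unit, and all three give neither a size nor a direction. No step beyond the scatter can therefore be expected in this assay on the evidence at hand, and the likeliest result is another limit. Compound 4 is expected to give about 12000 nM, with a range from 3000 nM to 50000 nM. The step that the limit leaves unreadable from compound 3 to compound 4 is an estimate only, not read from any measured step.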

Compound 4, concentration for 50% growth inhibition: > 10000 nM
Compound 4: only a limit was reported; the forecaster's own chance of this, stated with the estimate: 70%; the middle value lies beyond the limit too.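

No new step can be read between compound 4 and compound 1, compound 2 or compound 3 in this assay, because each value is a limit and not a number: the limit of > 10000 nM in this assay, at which 4 of the 4 values shown sit.

The compounds shown leave open whether lengthening the chain changes growth inhibition in this assay at all, in either size or direction.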